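Swapping the Sulfonamide Ring Substituent: Cyano to Chloro

The source may hold more compounds than are shown below. What is called first, only, known or untested is meant among the compounds shown, and "the series" means these compounds.

Of the compounds shown here, three built on one shared core have been tested in an assay on isolated protein for binding affinity to histamine H2 receptor (Homo sapiens); a lower number here means a stronger inhibitor, a higher number a weaker inhibitor. Compound 1 `Cc1ccc(S(=O)(=O)N[C@H]2CCN(CCCOc3ccc(C(=O)C4CC4)cc3)C2)cc1` carries a methyl group on the aromatic ring of the sulfonamide and gives 380 nM. Compound 2 `COc1ccc(S(=O)(=O)N[C@H]2CCN(CCCOc3ccc(C(=O)C4CC4)cc3)C2)cc1`, with a methoxy in place of that methyl, gives 1000 nM, and compound 3 `N#Cc1ccc(S(=O)(=O)N[C@H]2CCN(CCCOc3ccc(C(=O)C4CC4)cc3)C2)cc1`, with a cyano there, gives 1600 nM. Compound 3 shows the highest of the three numbers, though one of the two steps leading to it is only a 1.6-fold higher number from compound 2 to compound 3 (0.20 log units; within the scatter), while the other is a 4.2-fold higher number from compound 1 to compound 3 (0.62 log units; beyond the scatter).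

Compound 4 `O=C(c1ccc(OCCCN2CC[C@H](NS(=O)(=O)c3ccc(Cl)cc3)C2)cc1)C1CC1` differs from compound 3 in one place: chloro in place of cyano on an aromatic carbon. For the measured compounds named here, no measured step involves a chloro group, so the only guide is what the measured swaps at this aromatic carbon did: a 2.6-fold higher number from compound 1 to compound 2 (0.42 log units; beyond the scatter) and a 4.2-fold higher number from compound 1 to compound 3 (0.62 log units; beyond the scatter), both modest. A change at the same place is therefore expected to shift the number by a similarly modest amount. Since compound 3 stands highest of the three, a move toward the numbers of compound 1 or compound 2 is judged at least as likely as a further rise, so compound 4 is expected to give a somewhat lower number, a step of a 2.7-fold lower number from compound 3 to compound 4 (0.43 log units; beyond the scatter). The estimate for compound 4 is 600 nM, within 250 nM to 1500 nM.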

Compound 4, inhibition constant: 290 nM
Beside the measured number, compound 4's estimate is 2.1-fold (0.32 log units) above it; low and high end bracket the measured number.
By their numbers in this assay, from the lowest: compounds 4 and 1 (each within the scatter of the next); then compounds 2 and 3 (each within the scatter of the next).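

In this assay, the swap at this aromatic carbon, para to a large group, can lower the number as well as raise it: chloro in place of cyano gives a 5.5-fold lower number from compound 3 to compound 4 (0.74 log units; beyond the scatter) and chloro in place of methoxy gives a 3.4-fold lower number from compound 2 to compound 4 (0.54 log units; beyond the scatter) in the same direction. For the compounds shown here, until now, every change away from methyl had raised the number, so methyl might have seemed to be the one group that suits this position. Chloro shows otherwise, as a 1.3-fold lower number from compound 1 to compound 4 (0.12 log units; within the scatter) leaves the two groups indistinguishable, so the four compounds fall into two levels, with methyl and chloro at the lower one and methoxy and cyano at the higher one.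

Four groups at one carbon cannot say whether a bromo, a trifluoromethyl, an amine or a carboxylic acid here would join the lower level, go below it or rise above the higher one, or what a bare ring hydrogen would give. Nothing in the available data explains why the four groups divide in this way.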